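This account rests on a few compounds, and the source may have more. Where it says the series, first, only, none or still open, it means among the compounds named here.

Compound 1 `Cc1cccc(NC(=O)Nc2ccc(Sc3nc(C)cc(C)n3)cc2)c1`: 37000 nM in a functional assay on MCF7 cells (Homo sapiens) for cytotoxicity, read by MTT assay, with a stated time of 3 days; on this read-out lower numbers stand for stronger inhibition and higher numbers for weaker inhibition
Compound 2 `Cc1cc(C)nc(Sc2ccc(NC(=O)Nc3ccc(OC(F)(F)F)cc3)cc2)n1`: 41700 nM in this assay

For the measured compounds named here, of these two numbers, the one for compound 2 is the larger, yet its gap to compound 1 lies within the scatter, so the two compounds cannot be told apart on this read-out. Compound 3 `Cc1cc(C)nc(Sc2ccc(NC(=O)Nc3ccc(Cl)cc3)cc2)n1` is not yet measured; it differs from compound 2 by chloro in place of trifluoromethoxy on an aromatic carbon. Going by the values given here, no measured pair isolates this change, so nothing here points to a shift in either direction; the expected step of a 1.0-fold lower number from compound 2 to compound 3 (0.02 log units; within the scatter) is thus none beyond the scatter. For compound 3 the estimate in this assay is 40000 nM, within a range from 15000 nM to 100000 nM.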

Compound 3, half-maximal inhibitory concentration: 35300 nM
Estimate against measurement, compound 3: 1.1-fold (0.05 log units) above; the range from low to high includes it.
By their numbers in this assay, from the lowest: compounds 3, 1 and 2 (each within the scatter of the next).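

On an aromatic carbon para to a large group, chloro in place of trifluoromethoxy gives a 1.2-fold lower number from compound 2 to compound 3 (0.07 log units; within the scatter) in this assay, so this change shows no shift beyond the scatter, even with 1 heavy atom entering where 5 leave. Likewise, 4-chlorophenyl in place of 3-methylphenyl on an amide-type nitrogen gives a 1.0-fold lower number from compound 1 to compound 3 (0.02 log units; within the scatter), so these two compounds cannot be told apart either. Nothing available explains this result.

Going by these compounds, whether an amine or a carboxylic acid on this aromatic carbon would move the number beyond the scatter remains open.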